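Chloro for trifluoromethoxy on the aryl of compound 1

A few compounds are considered here, and "the series" means these few. Any claim that something is new, unique, unknown or untested is made for them only; others in the source may bear on it.

Among the measured compounds shown here, compound 1 `C[C@H](c1ccc(C(=O)NCCC(=O)O)cc1)N1C(=O)C(c2cccc(OC(F)(F)F)c2)=N[C@]12CC[C@@H](C(C)(C)C)CC2` gives 840 nM in a functional assay on CHO cells for antagonist activity at Glucagon receptor (Homo sapiens), read by cAMP accumulation, with stated times of 30 min and 45 min (a higher number here means a weaker inhibitor, a lower number a stronger inhibitor), the highest of the two numbers measured so far; compound 2 `CC1(CC[C@H](c2ccc(C(=O)NCc3nn[nH]n3)cc2)N2C(=O)C(c3cc(Cl)cc(Cl)c3)=N[C@]23CC[C@@H](C(C)(C)C)CC3)CC1` gives 100 nM in this assay, a gap beyond the scatter. Compound 3 `C[C@H](c1ccc(C(=O)NCCC(=O)O)cc1)N1C(=O)C(c2cccc(Cl)c2)=N[C@]12CC[C@@H](C(C)(C)C)CC2` is not yet measured. It differs from compound 1 by chloro in place of trifluoromethoxy on an aromatic carbon, placed on an aromatic carbon of a six-membered aromatic ring of carbon only. For the measured compounds named here, no measured pair shows this change alone, so a modest step toward a lower number is expected, possibly within the scatter. For compound 3 the estimate in this assay is 600 nM, range 250 nM to 1500 nM, a step of a 1.4-fold lower number from compound 1 to compound 3 (0.15 log units; within the scatter).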

Compound 3, half-maximal inhibitory concentration: 480 nM
Compound 3: middle estimate off by 1.3-fold (0.10 log units), on the high side; low and high end bracket the measured number.
By their numbers in this assay, from the lowest: compound 2; then compounds 3 and 1 (each within the scatter of the next).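

Going from 3-(trifluoromethoxy)phenyl to 3-chlorophenyl on the core of compound 1 gives the first single-change reading at this aromatic carbon: in this assay, a 1.8-fold lower number from compound 1 to compound 3 (0.24 log units; within the scatter). Replacing five heavy atoms with one therefore leaves the inhibitory readout within the scatter, so this carbon accepts either group in this series. No supporting measurement bears on the reason for this outcome.

On these data alone, a methoxy or an amine at this aromatic carbon remains open. Also open, as far as these compounds go, is what a second chloro on this ring would do as a single change.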